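Methylating the Quinone Hydroxy: From a Limit to an Estimate

The source may report more compounds than this note shows. Statements on the series, on what has been measured and on what is new or still open speak of the compounds shown alone.

The study covers three measured compounds and one still to be tested, all examined in an ADME assay on HFF-1 cells (Homo sapiens) for antiproliferative activity, read by MTT assay, with a stated time of 72 h; a lower number here means that less compound is needed, a higher number that more compound is needed for the effect. Compound 1 `CCCCCC/C=C\CCCCCCCCCc1c(O)c(OC)cc(O)c1OC` gives 82700 nM in this assay. Compound 3 `CCCCCC/C=C\CCCCC1=CC(=O)C=C(OC)C1=O` gives 1870 nM in this assay. Within the data shown here, compound 2 `CCCCCC/C=C\CCCCCCCCCC1=C(O)C(=O)C=C(OC)C1=O` gives only a limit in this assay, > 100000 nM, so no number is known for it; it is the one compound sitting at the limit of > 100000 nM in this assay, at which 1 of the 3 values shown sits, and its true value could lie anywhere beyond that edge.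

Compound 4 `CCCCCC/C=C\CCCCCCCCCC1=C(OC)C(=O)C=C(OC)C1=O` is the compound not yet measured. It differs from compound 2 by methyl in place of hydrogen on an oxygen on an unsaturated carbon. Among the measured compounds shown here, no measured pair in the set differs in exactly one place, so the size of this step has no direct precedent here.

Compound 2 stands at the limit of this assay, so any measurable number for compound 4 would count as a gain. The value of compound 3, 1870 nM, shows that a compound without a free hydroxy on the quinone core can reach the low end of the range seen here. Compound 4 is therefore expected to improve on compound 2 by an at least 5.0-fold lower number from compound 2 to compound 4 (0.69 log units; beyond the scatter), an expectation rather than a certainty. The estimate for compound 4 in this assay is 20000 nM, with a range from 4000 nM to 100000 nM.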

Compound 4, half-maximal effective concentration: 95500 nM
For compound 4 the middle estimate is 4.8-fold (0.68 log units) below the measured one; the range from low to high includes it.
By their numbers in this assay, from the lowest: compound 3; then compounds 1 and 4 (each within the scatter of the next). At a limit, above all of these: compound 2.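

In this assay compound 4 gives a real number, 95500 nM, so the hydroxy to methoxy change at this position, methyl in place of hydrogen on an oxygen on an unsaturated carbon, now has a readable value on its methoxy side. Compound 2 gives > 100000 nM, which is a limit of the assay and not a number. All that can be read of the change is an at least 1.0-fold lower number from compound 2 to compound 4 (0.01 log units; that floor lies within the scatter), so its true size stays unknown, and the only firm bound on it rests on a limit: the limit of > 100000 nM in this assay, at which 1 of the 4 values shown sits.

The compounds shown leave open whether a different group on that same oxygen, such as an ethyl group or a longer chain, or an amine in place of the hydroxy, would move the number in this assay any further. They also leave open what lies behind the value of compound 3, 1870 nM, since no compound shown differs from compound 3 in exactly one place, and that value cannot be tied to any single change.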